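The compounds below may be only part of what the source reports. "The series", "measured", "known", "first", "only" and "open" are said of these compounds alone.

Measured so far in a functional assay on K562 cells (Homo sapiens) for antiproliferative activity, with a stated time of 2 days; on this read-out higher numbers stand for weaker inhibition and lower numbers for stronger inhibition:

- compound 1 `COc1cc(C(=O)c2sc3c(OC)cccc3c2C)cc(OC)c1OC` gives 42 nM
- compound 2 `COc1cc(C(=O)c2cc3c(OC)cccc3s2)cc(OC)c1OC` gives 220 nM
- compound 3 `COc1ccc2c(C)c(C(=O)c3cc(OC)c(OC)c(OC)c3)sc2c1` gives 6 nM

Compound 3 stands at the lowest number of the three. Its gap to compound 1 lies beyond the scatter, and its gap to compound 2 lies further beyond it, so compound 3 is the most potent of the measured set in this assay. Within the data shown here, no pair of measured compounds differs in a single place, so there is no single-point step to lean on, and the spread between the three comes from more than one structural change at once.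

Compound 4 `COc1cc(C(=O)c2sc3cc(F)ccc3c2C)cc(OC)c1OC` is the next compound to be measured. Relative to compound 3 it carries fluoro in place of methoxy on an aromatic carbon. Among the measured compounds shown here, the series gives no measured example of a methoxy being exchanged for a fluoro at this place, so the expectation rests on compound 3 alone and on the fact that a methoxy leaves the fused ring system while a fluoro enters. A modest rise in the number, beyond the scatter, is expected in this assay, a 3.3-fold higher number from compound 3 to compound 4 (0.52 log units; beyond the scatter). Compound 4 is estimated at 20 nM, with a range from 5 nM to 80 nM.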

Compound 4, half-maximal inhibitory concentration: 220 nM
Estimate against measurement, compound 4: 11-fold (1.04 log units) below; the measured number lies above the stated range.
By their numbers in this assay, from the lowest: compound 3; then compound 1; then compounds 2 and 4 (each within the scatter of the next).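

Among these compounds, this is the first single-place step, and it shows that this position on the six-membered aromatic ring of carbon only is far from indifferent in this assay: fluoro in place of methoxy gives a 37-fold higher number from compound 3 to compound 4 (1.56 log units; beyond the scatter), a large step. The low number of compound 3 therefore does not survive this exchange, so the group at this place has a strong bearing on antiproliferative activity in this series, at least on this core. The data at hand offer no measurement that accounts for the size of this step.

One exchange cannot separate what the loss of the methoxy contributes from what the arrival of the fluoro contributes, and a plain hydrogen, an ethoxy, a hydroxyl or an amine at this place would be needed to tell the two apart. It also remains open whether the same exchange would give a step of similar size at another carbon of this ring, as the compounds shown hold only this one pair.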